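Phenyl in place of isopentyloxy: working notes

The compounds below may be only part of what the source reports. "The series", "measured", "known", "first", "only" and "open" are said of these compounds alone.

- compound 1 `CCCCOc1ccc(-c2c(C)[nH]c(=O)n2C2CCCCC2)cc1` at 13900 nM
- compound 2 `Cc1[nH]c(=O)n(C2CCCCC2)c1-c1ccc(OCCC(C)C)cc1` at 7200 nM

Both numbers come from a functional assay on brain (Rattus norvegicus, strain Wistar) for inhibition (on this read-out lower numbers stand for stronger inhibition and higher numbers for weaker inhibition), and they are not separated there. For the measured compounds named here, compound 2 stands level with the only other measured compound at 7200 nM on this read-out.

Compound 3 `Cc1[nH]c(=O)n(C2CCCCC2)c1-c1ccc(-c2ccccc2)cc1` remains unmeasured. It carries phenyl in place of isopentyloxy on an aromatic carbon, para to a large group, and the swap counts as phenyl in place of isopentyloxy on an aromatic carbon in full.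

Going by the values given here, only one measured step bears on this, and it bears indirectly. Among the compounds with values here, it puts methyl in place of hydrogen on a saturated chain carbon, and its size of a 1.9-fold lower number from compound 1 to compound 2 (0.29 log units; within the scatter) gives the only guide available. Within the data shown here, no measured compound has a ring in this place, so the swap itself is untested.

In this assay the expectation is therefore no step beyond the scatter, with neither direction favoured. The expected change is a 1.1-fold higher number from compound 2 to compound 3 (0.05 log units; within the scatter) on this thin evidence. The estimate for compound 3 is 8000 nM within a range of 2500 nM to 26000 nM and that range is deliberately kept wide.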

Compound 3, half-maximal inhibitory concentration: 10900 nM
Compound 3: the middle estimate sits 1.4-fold (0.13 log units) below what was measured; measured number inside the range.
By their numbers in this assay, from the lowest: compounds 2, 3 and 1 (each within the scatter of the next).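

In this assay, for the compounds shown here, the aromatic carbon para to a large group now carries a ring for the first time: phenyl in place of isopentyloxy gives a 1.5-fold higher number from compound 2 to compound 3 (0.18 log units; within the scatter) and phenyl in place of butoxy gives a 1.3-fold lower number from compound 1 to compound 3 (0.11 log units; within the scatter) at the same carbon. Across these three compounds, this position therefore takes a six-membered aromatic ring of carbon only without a step beyond the scatter, even though the change removes the one hydrogen-bond acceptor of the chain and replaces an open chain with a ring, so neither feature separates the compounds on this read-out. No measurement bears on why the numbers stay together at this position.

Going by these compounds alone, every step so far lies within the scatter, so it remains open whether an amine, a carboxylic acid or a longer chain such as octyloxy on this aromatic carbon would give a step beyond it. Also open, from the compounds shown here alone, is whether a phenyl carrying a nitrile or a hydroxyl group would match plain phenyl, which would show whether the ring itself can be varied at this position.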